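Swapping a Methylsulfonyl for a Carbamoyl Group

This account rests on a few compounds, and the source may have more. Where it says the series, first, only, none or still open, it means among the compounds named here.

Compound 1 `O=C(c1ccccc1)N1CCC(N(C2CC2)S(=O)(=O)c2cccc(C(F)(F)F)c2)CC1` and compound 2 `CS(=O)(=O)c1ccc(C(=O)N2CCC(N(C3CC3)S(=O)(=O)c3cccc(C(F)(F)F)c3)CC2)cc1` share one core and differ at a single aromatic carbon. In an assay on HEK293 cells for inhibition of Voltage-dependent N-type calcium channel subunit alpha-1B (Homo sapiens), read by FLIPR and calcium flux, tested at 1 uM (a higher number here means more inhibition at the concentration tested (going by the name of the read-out), a lower number less inhibition), compound 1 gives 42% and compound 2 gives 52%; the step of a number 10 percentage points higher from compound 1 to compound 2 (within the scatter) lies within the scatter, so the two cannot be told apart. Among the measured compounds shown here, compound 2 therefore stands at the upper end of the two numbers, with compound 1 as its only neighbour and no measured step beyond the scatter anywhere. Compound 3 `NC(=O)c1ccccc1C(=O)N1CCC(N(C2CC2)S(=O)(=O)c2cccc(C(F)(F)F)c2)CC1` is not yet measured; its change from compound 2 is 2-carbamoylphenyl in place of 4-(methylsulfonyl)phenyl on a carbonyl carbon. For the measured compounds named here, the only known step concerns a different group, so it offers little guidance here. With both measured numbers close together, a value near theirs is expected for compound 3 in this assay, namely 45% with a range from 25% to 65%, which amounts to an expected step of a number 7 percentage points lower from compound 2 to compound 3 (within the scatter) that should stay within the scatter.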

Compound 3, a percentage reported as inhibition, at one concentration (the size of the read-out at that concentration, not a potency): 15%
Estimate against measurement, compound 3: 30 percentage points above; the whole stated range lies above it.
By their numbers in this assay, from the lowest: compound 3; then compounds 1 and 2 (each within the scatter of the next).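

Among the compounds shown here, this position is the first place where a change clearly moves the read-out in this assay: putting 2-carbamoylphenyl where 4-(methylsulfonyl)phenyl stood gives a number 37 percentage points lower from compound 2 to compound 3 (beyond the scatter). The loss is not just a matter of removing the methylsulfonyl group, as carbamoyl in place of hydrogen on an aromatic carbon also gives a number 27 percentage points lower from compound 1 to compound 3 (beyond the scatter), so the carbamoyl-bearing ring falls short of both the ring with hydrogen and the ring with methylsulfonyl. Nothing measured here explains this drop in inhibition.

Going by these compounds, whether the loss belongs to the carbamoyl group itself or to where it sits on the aromatic ring stays open. Also open, on these data alone, is how a carboxylic acid or an amine would read in place of the carbamoyl group.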